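A few compounds are considered here, and "the series" means these few. Any claim that something is new, unique, unknown or untested is made for them only; others in the source may bear on it.

Compound 1, `Cc1ccc(CNC(=O)C(CCN)N(C)CCC=C(c2sccc2C)c2sccc2C)cc1`, carries an aminomethyl group on the chain next to its amide and a 4-methylbenzyl group on the amide nitrogen. In a physicochemical assay for lipophilicity, read by HPLC (on this read-out higher numbers stand for higher lipophilicity and lower numbers for lower lipophilicity), compound 1 gives 6.61, the highest of the three numbers here. Its nearest neighbour is compound 3, `Cc1ccc(CNC(=O)C(CC(C)O)N(C)CCC=C(c2sccc2C)c2sccc2C)cc1`, which in this assay gives 6.15; that pair is linked by a single change, a number 0.46 log units lower from compound 1 to compound 3 (beyond the scatter). Compound 2, `Cc1ccsc1C(=CCCN(C)C(CCO)C(=O)NCc1ccccc1)c1sccc1C`, differs from compound 1 in more than one place; in this assay compound 2 gives 5.71, the lowest of the three.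

Compound 4, `Cc1ccsc1C(=CCCN(C)C(CCN)C(=O)NCc1ccc(Cl)cc1)c1sccc1C`, is compound 1 with one change: chloro in place of methyl on an aromatic carbon. For the measured compounds named here, none of the measured steps touches the benzyl ring, so no step here bears directly on this change; the step from compound 1 to compound 3 concerns the chain and not the ring. Swapping one small ring substituent for another of the same size is expected to move lipophilicity only slightly, if at all, in this assay. The expected step is therefore a number 0.14 log units higher from compound 1 to compound 4 (within the scatter), at or just beyond the edge of the scatter and upward rather than downward. Compound 4 is accordingly estimated at 6.75 in this assay, with a range from 6.4 to 7.1.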

Compound 4, partition coefficient: 5.85
For compound 4 the middle estimate is 0.90 log units above the measured one; measured number below the stated range.
By their numbers in this assay, from the lowest: compounds 2, 4 and 3 (each within the scatter of the next, the first and the last beyond it); then compound 1.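

In this assay, chloro and methyl do not prove interchangeable on this aromatic carbon, para to a large group: the swap gives a number 0.76 log units lower from compound 1 to compound 4 (beyond the scatter), although one heavy atom simply replaces another and the counts of hydrogen-bond donors and acceptors and the net charge all stay the same. For the compounds shown here, until now the only single-change step lay on the chain, a number 0.46 log units lower from compound 1 to compound 3 (beyond the scatter), and this new step shows that a change on the benzyl ring can also move the number beyond the usual scatter. No measurement available here explains why this swap lowers the number.

Going by these compounds alone, whether chloro in place of methyl gives a similar step when the chain carries the 1-hydroxyethyl group of compound 3 remains open, as no matched pair tests the ring change on that chain. Going by these compounds, how the number responds to other groups at this same ring position, such as fluoro, bromo, methoxy or trifluoromethyl, also remains open, so a single swap cannot yet be extended into a trend.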